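The source may report more compounds than this note shows. Statements on the series, on what has been measured and on what is new or still open speak of the compounds shown alone.

Compound 1 `COc1cccc(CNCCCNc2ccnc3cc(CCC(C)C)ccc23)c1O` and compound 2 `COc1cccc(CNCCCNc2ccnc3cc(-c4cc(C(F)(F)F)cc(C(F)(F)F)c4)ccc23)c1O` share one core and differ only in the group carried on it. In a physicochemical assay for acid dissociation, compound 1 gives 9.47, and compound 2 gives 9.47, level with compound 1 at the digits shown, within the scatter. Compound 3 `COc1ccc(F)cc1CNCCCNc1ccnc2cc(-c3cc(C(F)(F)F)cc(C(F)(F)F)c3)ccc12` is not yet measured; it differs from compound 2 by 5-fluoro-2-methoxyphenyl in place of 2-hydroxy-3-methoxyphenyl on a saturated chain carbon bound to an amine nitrogen. For the measured compounds named here, no step between measured compounds bears on this change. Compound 3 is expected to sit slightly lower in this assay, with an estimated step of a number 0.27 log units lower from compound 2 to compound 3 (within the scatter) near the edge of the scatter. The estimate for compound 3 is 9.2, from 8.6 to 9.8.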

Compound 3, acid dissociation constant: 9.47
Compound 3: middle estimate off by 0.27 log units, on the low side; low and high end bracket the measured number.
By their numbers in this assay, from the lowest: compounds 1, 2 and 3 (each within the scatter of the next).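

In this assay, 5-fluoro-2-methoxyphenyl in place of 2-hydroxy-3-methoxyphenyl on a saturated chain carbon bound to an amine nitrogen gives no change at the digits printed from compound 2 to compound 3 (within the scatter) in this one pair. For the compounds shown here, this is the first reading of a change at this place, as compounds 1 and 2 differ only in the other group on the shared core. The read-out stays level here although the entering group has 0 hydrogen-bond donors and the leaving group has 1. From the compounds shown here alone, whether an aminophenyl or a carboxyphenyl at this place would stay level remains open. No measurement at hand accounts for the level result.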